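Cyano for benzoyl on a vinyl sulfone indole series

The source may hold more compounds than are shown below. What is called first, only, known or untested is meant among the compounds shown, and "the series" means these compounds.

Measured compounds in a functional assay on T47D cells (Homo sapiens) for inhibition, read by sulforhodamine B assay, with a stated time of 48 h; a higher number here means a weaker inhibitor of growth, a lower number a stronger inhibitor of growth:
compound 1, `O=C(/C(=C\c1c(-c2ccccc2)[nH]c2ccccc12)S(=O)(=O)c1ccccc1)c1ccccc1`, 3400 nM
compound 2, `COc1ccc(-c2[nH]c3ccc(OC)cc3c2/C=C(\C#N)S(=O)(=O)c2ccccc2)cc1`, 905 nM
compound 3, `COc1ccc2[nH]c(-c3ccccc3)c(C=C(C#N)C#N)c2c1`, 2300 nM

Compound 1 has the highest of the three numbers in this assay . Its gap to compound 3 lies within the usual scatter of the measurement, so nothing can be said about an order between them. Its gap to compound 2, which gives the lowest number of the three, lies beyond the scatter.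

The unmeasured compound 4, `N#C/C(=C\c1c(-c2ccccc2)[nH]c2ccccc12)S(=O)(=O)c1ccccc1`, differs from compound 1 in one place: cyano in place of benzoyl on a double-bonded chain carbon bound to a double-bonded chain carbon and a sulfonyl sulfur. Going by the values given here, no measured pair shows this exact change on its own. Compound 2 carries the same cyano-bearing double bond together with two methoxy groups and gives 905 nM, while compound 3 carries two cyano groups and gives 2300 nM; both numbers sit below that of compound 1.

On that basis the step of a 2.3-fold lower number from compound 1 to compound 4 (0.36 log units; beyond the scatter) is expected to run toward a lower number, of moderate size and probably just beyond the scatter. Compound 4 is therefore estimated at 1500 nM, with a likely range from 500 nM to 4500 nM.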

Compound 4, concentration for 50% growth inhibition: 3800 nM
Compound 4: middle estimate off by 2.5-fold (0.40 log units), on the low side; measured number inside the range.
By their numbers in this assay, from the lowest: compound 2; then compounds 3, 1 and 4 (each within the scatter of the next).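

In this assay, cyano in place of benzoyl on a double-bonded chain carbon bound to a double-bonded chain carbon and a sulfonyl sulfur gives a 1.1-fold higher number from compound 1 to compound 4 (0.05 log units; within the scatter), so on the core of compound 1 the two groups cannot be told apart in this read-out. The change removes a six-membered aromatic ring and leaves a much smaller group of 2 heavy atoms, which shows that the benzoyl ring is not required at this place for the growth inhibition seen with compound 1. Nothing at hand accounts for this result.

The compounds shown leave open whether a carboxylic acid or a primary amide at this place would shift the number. They also leave open whether a single methoxy group on the core of compound 4 would do so.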